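Changing the Aryl Group on the Sulfonyl Nitrogen

The source may hold more compounds than are shown below. What is called first, only, known or untested is meant among the compounds shown, and "the series" means these compounds.

Two measured compounds share one core bearing a sulfonyl group on an aromatic nitrogen. Compound 1 `COC(=O)c1cc(=O)c2c(OC)cc(OC)cc2n1S(=O)(=O)c1ccc(C)cc1` was tested in a functional assay on HepG2 cells (Homo sapiens) for antiproliferative activity, with a stated time of 72 h (on this read-out lower numbers stand for an effect already at smaller amounts and higher numbers for an effect only at larger amounts of compound), and gave only a limit of the assay, > 20000 nM. Compound 2 `COc1ccc(-c2cc(=O)c3c(OC)cc(OC)cc3n2S(=O)(=O)c2ccc(C)c([N+](=O)[O-])c2)cc1` carries a 4-methyl-3-nitrophenyl group on the sulfonyl sulfur, and in this assay compound 2 likewise reached only a limit, > 51700 nM. For the measured compounds named here, compound 2 thus stands at one of the two limits on record, (the limit of > 51700 nM in this assay, at which 1 of the 2 values shown sits), and compound 1 stands at the other, (the limit of > 20000 nM in this assay, at which 1 of the 2 values shown sits); no numbered value has been obtained for either, so no measured step exists between them.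

Compound 3 `COc1ccc(-c2cc(=O)c3c(OC)cc(OC)cc3n2S(=O)(=O)c2cc(Cl)cc(Cl)c2O)cc1` differs from compound 2 in one place: 3,5-dichloro-2-hydroxyphenyl in place of 4-methyl-3-nitrophenyl on a sulfonyl sulfur. With both measured compounds sitting at limits, there is no basis for expecting a large shift in this assay, and the estimate for the step from compound 2 to compound 3 is an at least 1.2-fold lower number from compound 2 to compound 3 (0.11 log units; that floor lies within the scatter), which is expected to stay close to the scatter. Compound 3 is accordingly expected to give about 40000 nM, within a range from 8000 nM to 120000 nM, most likely again as a limit.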

Compound 3, half-maximal effective concentration: > 37900 nM
Compound 3 was reported as a limit; the forecaster's own chance of this, stated with the estimate: 70%; the middle value does not contradict the limit.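

In this assay compound 3 gave only a limit, > 37900 nM. For the compounds shown here, with compound 2 also standing at a limit, no step between compound 2 and compound 3 can be read. The compounds shown leave open whether 3,5-dichloro-2-hydroxyphenyl in place of 4-methyl-3-nitrophenyl on a sulfonyl sulfur changes the read-out at all.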